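This account rests on a few compounds, and the source may have more. Where it says the series, first, only, none or still open, it means among the compounds named here.

Of the compounds shown here, three that share one core have been measured in an assay on cells with melanin-concentrating hormone receptor 1 (Homo sapiens) as the target, read by radioligand binding; a lower number here means a stronger inhibitor, a higher number a weaker inhibitor. Compound 1, `CCOCCOc1cccc2ccc(N)nc12`, carries an ethoxy on the saturated chain; in this assay compound 1 reaches only the limit > 2000 nM, which is a boundary of the assay rather than a number. Compound 2, `Nc1ccc2cccc(OCCC3CCCCC3)c2n1`, carries a cyclohexyl at that place and in this assay gives 808 nM. Compound 3, `CCCOc1cccc2ccc(N)nc12`, carries a methyl there and in this assay gives 1100 nM. Compound 3 thus has the higher of the two plain numbers, although its gap to compound 2 lies within the scatter.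

The next step changes (isopropoxy in place of methyl on a saturated chain carbon, two bonds along the chain from an oxygen on an aromatic ring), giving compound 4, `CC(C)OCCOc1cccc2ccc(N)nc12`. Within the data shown here, two measured steps bear on this. The change an at least 1.8-fold lower number from compound 1 to compound 3 (0.25 log units; that floor lies within the scatter) shows the move from ethoxy to methyl lowering the number somewhat, and an at least 2.4-fold lower number from compound 1 to compound 2 (0.39 log units; beyond the scatter) shows a similar direction for cyclohexyl. Compound 4 reverses that direction, restoring an ether at the same place, so a higher number than for compound 3 is expected, with a real chance that only a limit is reported. Compound 4 is therefore estimated at 2000 nM, within 900 nM to 5000 nM, an expected step of a 1.8-fold higher number from compound 3 to compound 4 (0.26 log units; within the scatter).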

Compound 4, half-maximal inhibitory concentration: > 2000 nM
Compound 4 was reported as a limit (the forecaster's own chance of this, stated with the estimate: 45%); the middle value sits exactly at the limit.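

In this assay, the result for compound 4 is a limit and not a number, so its steps give only floors. Isopropoxy in place of cyclohexyl brings an at least 2.4-fold higher number from compound 2 to compound 4 (0.39 log units; beyond the scatter), while isopropoxy in place of methyl brings an at least 1.8-fold higher number from compound 3 to compound 4 (0.25 log units; that floor lies within the scatter), so only the comparison with the cyclohexyl group shows a loss beyond the scatter, and a branched ether end gives no measurable gain over the ethoxy of compound 1. The step between compound 1 and compound 4 cannot be read, because both results are limits: the limit of > 2000 nM in this assay, at which 2 of the 4 values shown sit.

As far as these compounds go, the order of the two ether-bearing compounds therefore stays unknown. Also open, from the compounds shown here alone, is whether an amine, a carboxylic acid or a longer plain carbon chain at this place would give a lower number than compound 2, at 808 nM.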